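Toward compound 4: changing the aryl substituent of compound 3

A few compounds are considered here, and "the series" means these few. Any claim that something is new, unique, unknown or untested is made for them only; others in the source may bear on it.

Measured compounds:
compound 1, `CCO/C=C(\C#N)C(=O)N/N=C(\C)c1ccc(NS(=O)(=O)c2ccc(Cl)cc2)cc1`, gives 16800 nM in a functional assay on HepG2 cells (Homo sapiens) for cytotoxicity, read by sulforhodamine B assay, with a stated time of 48 h; a higher number here means a weaker inhibitor, a lower number a stronger inhibitor
compound 2, `CSC(SC)=C(C#N)C(=O)N/N=C(\C)c1ccc(NS(=O)(=O)c2ccc(Cl)cc2)cc1`, gives 19400 nM in this assay
compound 3, `CCOC(=O)c1c(-c2ccccc2OC)c(C#N)c(=O)n(/N=C(\C)c2ccc(NS(=O)(=O)c3ccc(Cl)cc3)cc2)c1N`, gives 11400 nM in this assay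

Compound 3 has the lowest of the three numbers, but its gaps to compound 1 and to compound 2 are both within the scatter, so the three measured compounds cannot be ordered against one another.

Compound 4, `CCOC(=O)c1c(-c2ccc([N+](=O)[O-])cc2)c(C#N)c(=O)n(/N=C(\C)c2ccc(NS(=O)(=O)c3ccc(Cl)cc3)cc2)c1N`, is not yet measured. It differs from compound 3 in one place: 4-nitrophenyl in place of 2-methoxyphenyl on an aromatic carbon.

For the measured compounds named here, only one measured step exists, a 1.2-fold higher number from compound 1 to compound 2 (0.06 log units; within the scatter), and it concerns a different part of the molecule, the group on the carbonyl carbon of compounds 1 and 2. Going by the values given here, no measured pair varies the group that changes between compound 3 and compound 4. Among the compounds with values here, with the one step at hand showing no movement beyond the scatter, and no step at the relevant position at all, no direction can be read for compound 4; the expectation is a step of a 1.1-fold higher number from compound 3 to compound 4 (0.02 log units; within the scatter), within the scatter, in this assay.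

For compound 4 the estimated value in this assay is 12000 nM, expected between 4500 nM and 32000 nM.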

Compound 4, half-maximal inhibitory concentration: 41100 nM
Beside the measured number, compound 4's estimate is 3.4-fold (0.53 log units) below it; the whole stated range lies below it.
By their numbers in this assay, from the lowest: compounds 3, 1 and 2 (each within the scatter of the next); then compound 4.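

For the compounds shown here, the aryl group opposite the ring nitrogen is the first place where a single change moves the number beyond the scatter: in this assay, 4-nitrophenyl in place of 2-methoxyphenyl gives a 3.6-fold higher number from compound 3 to compound 4 (0.56 log units; beyond the scatter). Going by these compounds alone, the only earlier step, a 1.2-fold higher number from compound 1 to compound 2 (0.06 log units; within the scatter), concerned the group on the carbonyl carbon, so it gave no sign that this position could respond. No measurement shown here bears on what lies behind the rise.

The change swaps the substituent and its place on the phenyl ring together, so the two remain unseparated. A 4-methoxyphenyl, a 2-nitrophenyl, a plain phenyl or a 4-aminophenyl at this position would be needed to say which of them carries the step.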